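The source may hold more compounds than are shown below. What is called first, only, known or untested is meant among the compounds shown, and "the series" means these compounds.

Working notes on the series. Compound 1 `C/C(=C\c1cc(-c2ccccc2)co1)C(N)=O` and compound 2 `C/C(=C\c1cc(-c2ccc(C)cc2)co1)C(N)=O` share one core; compound 3 `C/C(=C\c1nc(-c2ccccc2)cs1)C(N)=O` and compound 4 `C/C(=C\c1nc(-c2ccc(C)cc2)cs1)C(N)=O` share another, and the difference between the two cores is not broken down here. In a functional assay on MCF7 cells (Homo sapiens) for cytotoxicity, read by CCK-8 assay, with a stated time of 24 h (a lower number here means a stronger inhibitor, a higher number a weaker inhibitor), compound 1 gives 3340 nM, compound 2 gives 1630 nM and compound 3 gives 2380 nM. The values of compound 3 and compound 1 lie within the scatter of each other, as do those of compound 3 and compound 2. Going by the values given here, the only counted change within a core is methyl in place of hydrogen on an aromatic carbon, which gave a 2.0-fold lower number from compound 1 to compound 2 (0.31 log units; beyond the scatter). The same change, (methyl in place of hydrogen on an aromatic carbon), takes compound 3 to compound 4. Resting on that single step, the step to compound 4 is expected to be a 1.9-fold lower number from compound 3 to compound 4 (0.28 log units; within the scatter), because compound 2 showed a 2.0-fold lower number from compound 1 to compound 2 (0.31 log units; beyond the scatter). Compound 4 is therefore estimated at 1250 nM, expected to fall between 600 nM and 2600 nM.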

Compound 4, half-maximal inhibitory concentration: > 50000 nM
Compound 4: a limit, no number; the forecaster's own chance of this, stated with the estimate: 3%; middle value at least 40-fold (1.60 log units) away from the limit.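

In this assay, methyl in place of hydrogen on an aromatic carbon gave an at least 21-fold higher number from compound 3 to compound 4 (1.32 log units; beyond the scatter), so the change did not carry from one core to the other: the same change on two cores in this assay, a 2.0-fold lower number (0.31 log units; beyond the scatter) from compound 1 to compound 2 and an at least 21-fold higher number (1.32 log units; beyond the scatter) from compound 3 to compound 4, at least 43-fold (1.63 log units) apart, beyond the scatter of two such steps Compound 4 gives > 50000 nM, which is a limit of the assay and not a number: the limit of > 50000 nM in this assay, at which 1 of the 4 values shown sits. This shows that, for these two cores, the step on one did not predict the step on the other; it does not show why the steps differ or give the exact size of the step to compound 4, and a single pair on each core sets no general rule.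

The compounds shown leave open whether a chlorine, a methoxy group or an amine on the same aromatic carbon would follow the pair on the core of compound 1 or the pair on the core of compound 3. They also leave open whether the sharp rise on the core of compound 3 is particular to methyl.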